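Aryl in place of pyrazinyl on the ring amide nitrogen

The source may hold more compounds than are shown below. What is called first, only, known or untested is meant among the compounds shown, and "the series" means these compounds.

Compound 1 `O=C(NCCCCc1ccccc1)c1cccc(C2SCC(=O)N2c2cccc(-c3c[nH]nn3)c2)c1` gives 110 nM in a functional assay on HOS-TE85 cells (Homo sapiens) for inhibition, read by CCK-8 assay, with a stated time of 72 h (a lower number here means a stronger inhibitor, a higher number a weaker inhibitor), and compound 2 `O=C(NCCCCc1ccccc1)c1cccc(C2SCC(=O)N2c2ccc(C3CC3)cc2)c1` gives 217 nM in this assay; the step of a 2.0-fold higher number from compound 1 to compound 2 (0.30 log units; within the scatter). Compound 3 `O=C(NCCCCc1ccccc1)c1cccc(C2SCC(=O)N2c2cnccn2)c1` reaches only > 1000 nM in this assay; this is a limit of the measurement, not a number (the limit of > 1000 nM in this assay, at which 1 of the 3 values shown sits). The steps of an at least 9.0-fold higher number from compound 1 to compound 3 (0.95 log units; beyond the scatter) and an at least 4.6-fold higher number from compound 2 to compound 3 (0.66 log units; beyond the scatter) both point the same way. Compound 4 `COc1ccc(F)cc1N1C(=O)CSC1c1cccc(C(=O)NCCCCc2ccccc2)c1` differs from compound 3 by 5-fluoro-2-methoxyphenyl in place of pyrazin-2-yl on an amide-type nitrogen in a ring, returning to a six-membered aromatic ring of carbon only on that nitrogen, as in compound 1 and compound 2. A lower number is therefore expected for compound 4, of a size near those two steps, the estimated step being an at least 3.3-fold lower number from compound 3 to compound 4 (0.52 log units; beyond the scatter). Compound 4 is expected near 300 nM, between 100 nM and 1000 nM.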

Compound 4, half-maximal inhibitory concentration: 8.8 nM
Estimate against measurement, compound 4: 34-fold (1.53 log units) above, and the stated range ends above it.
By their numbers in this assay, from the lowest: compound 4; then compounds 1 and 2 (each within the scatter of the next). At a limit, above all of these: compound 3.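

On the amide-type nitrogen, a carbon-only aromatic ring does not by itself fix the level in this assay: the substituents on it matter, with a 25-fold lower number from compound 2 to compound 4 (1.39 log units; beyond the scatter) and a 13-fold lower number from compound 1 to compound 4 (1.10 log units; beyond the scatter). Against pyrazin-2-yl, the change gives an at least 110-fold lower number from compound 3 to compound 4 (2.05 log units; beyond the scatter). Compound 3 stands at a limit of the measurement, not at a number: the limit of > 1000 nM in this assay, at which 1 of the 4 values shown sits.

From the compounds shown here alone, it remains open whether the fluorine or the methoxy group accounts for the lower number of compound 4, as neither appears alone on that ring. Also open, going by these compounds, is whether an amine or a carboxylic acid on the same ring would keep it.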